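The source may report more compounds than this note shows. Statements on the series, on what has been measured and on what is new or still open speak of the compounds shown alone.

Measured so far:
Compound 1 `O=C(NC1CCN(CC2CC2)C1)c1cc(-c2ccc(NS(=O)(=O)c3cccc(Cl)c3Cl)cc2)nc2[nH]ncc12`: 1 nM
Compound 2 `CC(C)NC(=O)c1cc(-c2ccc(NS(=O)(=O)c3cccc(Cl)c3Cl)cc2)nc2[nH]ncc12`: 68 nM

In an assay for inhibition of serine/threonine-protein kinase Sgk1 (Homo sapiens), with stated times of 30 min and 60 min, in the presence of a further agent that is not named here (on this read-out higher numbers stand for weaker inhibition and lower numbers for stronger inhibition), compound 2 gives the higher of the two numbers, and its nearest neighbour is compound 1, reached by the step of a 68-fold higher number from compound 1 to compound 2 (1.83 log units; beyond the scatter). That single step shows that the group on the amide-type nitrogen can move the read-out a long way. Compound 3 `NCCNC(=O)c1cc(-c2ccc(NS(=O)(=O)c3cccc(Cl)c3Cl)cc2)nc2[nH]ncc12` alters exactly this position: 2-aminoethyl in place of isopropyl on an amide-type nitrogen. Going by the values given here, the one measured step that bears on it is the exchange of the large ring-bearing group of compound 1 for isopropyl, which cost a great deal; the entering 2-aminoethyl group, with its one hydrogen-bond donor and one acceptor, is not itself paired with any measurement. A step back toward the stronger side, of moderate size, is therefore expected, from compound 2 to compound 3: a 5.7-fold lower number from compound 2 to compound 3 (0.75 log units; beyond the scatter). For compound 3 the estimated value in this assay is 12 nM, within a range from 2 nM to 70 nM.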

Compound 3, half-maximal inhibitory concentration: < 1 nM
Compound 3 ended at the assay's limit (the forecaster's own chance of this, stated with the estimate: 2%); middle value at least 12-fold (1.07 log units) from the limit.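

Replacing isopropyl with 2-aminoethyl on the amide-type nitrogen gives an at least 68-fold lower number from compound 2 to compound 3 (1.83 log units; beyond the scatter) in this assay. Compound 1 had suggested that a large ring-bearing group might be needed for a low number, but compound 3 reaches the low end with a chain of 3 heavy atoms and no ring, the same heavy-atom count as isopropyl, so the identity of the atoms at this position matters and not only the size of the group. Replacing 1-(cyclopropylmethyl)pyrrolidin-3-yl with 2-aminoethyl on the amide-type nitrogen gives a number no higher from compound 1 to compound 3 (the limit leaves the size open) and no more than that can be said of this step. The value of compound 3 is a limit and not a number: the limit of < 1 nM in this assay, at which 1 of the 3 values shown sits.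

The compounds shown do not tell whether the gain depends on the terminal amine itself, which a 2-hydroxyethyl group, with a hydroxyl in its place, would test. They also leave open how the length of the chain counts, which a longer 3-aminopropyl chain would test.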